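Trading a hydroxyphenylethyl arm for cyclopropyl on the shared core

The compounds below may be only part of what the source reports. "The series", "measured", "known", "first", "only" and "open" are said of these compounds alone.

Compound 1 `OC(Cc1ccccc1)CN1CCC(NCCSC(c2ccc(F)cc2)c2ccc(F)cc2)CC1` is the reference point in this small set. Going by the values given here, in an assay on membranes from striatum (strain Sprague-Dawley) for displacement of a labelled ligand from sodium-dependent dopamine transporter (Rattus norvegicus), read by scintillation counting, with a stated time of 120 min (on this read-out lower numbers stand for stronger inhibition and higher numbers for weaker inhibition), compound 1 gives 31.4 nM, the lower of the two numbers measured, and the only other value comes from compound 2 `O=C(c1ccc(F)cc1)N1CCC(NCC[S+]([O-])C(c2ccc(F)cc2)c2ccc(F)cc2)CC1`, which in this assay gives 77.2 nM; the two differ in several places at once, so their values can only be placed side by side, not traced to one change.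

Compound 3 `Fc1ccc(C(SCCNC2CCN(CC3CC3)CC2)c2ccc(F)cc2)cc1` differs from compound 1 in one place: cyclopropyl in place of 1-hydroxy-2-phenylethyl on a saturated chain carbon bound to an amine nitrogen in a ring. The large arm carrying a ring and a hydroxyl is thus replaced by a small three-membered ring, leaving the rest of the shared core untouched. Among the compounds with values here, no pair of measured compounds separated by a single change exists here, so the size of this step cannot be read from the data. A group of this size is nonetheless a substantial change, and the expectation is a moderate move toward weaker inhibition, plausibly beyond the scatter, though a flat result cannot be excluded.

For compound 3 the expected inhibition constant in this assay is 70 nM, with a range from 20 nM to 250 nM.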

Compound 3, inhibition constant: 407 nM
Compound 3: the middle estimate sits 5.8-fold (0.76 log units) below what was measured, outside the stated range (above it).
By their numbers in this assay, from the lowest: compound 1; then compound 2; then compound 3.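

Going by these compounds alone, this is the first step in the set that can be traced to one place, and in this assay it is large: a 13-fold higher number from compound 1 to compound 3 (1.11 log units; beyond the scatter), with the rest of the shared core unchanged. The group on the saturated chain carbon bound to an amine nitrogen in a ring therefore strongly affects the result, and cyclopropyl at this place gives much weaker inhibition than 1-hydroxy-2-phenylethyl. Nothing measured here explains why the number rises, so the size of the step is all that can be stated.

The change removes the six-membered aromatic ring and the hydroxyl together, and the compounds shown cannot tell whether one of them or both together account for the step. A plain 2-phenylethyl group, which keeps the ring without the hydroxyl, and a 2-hydroxypropyl group, which keeps the hydroxyl without the ring, would be the natural comparisons for pulling these two parts apart.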